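A few compounds are considered here, and "the series" means these few. Any claim that something is new, unique, unknown or untested is made for them only; others in the source may bear on it.

Working notes on the series. The shared core is carried unchanged by compound 1 `COc1cc2ncnc(N3CCc4ccccc43)c2cc1NC(=O)C=C(C)C` and compound 2 `CCC/C=C/C(=O)Nc1cc2c(N3CCc4ccccc43)ncnc2cc1OC`; the two differ only in the chain on the carbonyl carbon of the amide. In a functional assay on MCF7 cells (Homo sapiens) for antiproliferative activity, read by MTT assay, with a stated time of 72 h (on this read-out lower numbers stand for stronger inhibition and higher numbers for weaker inhibition), compound 1 gives 6390 nM and compound 2 gives 3160 nM. The step of a 2.0-fold lower number from compound 1 to compound 2 (0.31 log units; beyond the scatter) is modest but beyond the scatter, and on the two numbers available compound 2 stands as the lower of the pair.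

Compound 3 `COc1cc2ncnc(N3CCc4ccccc43)c2cc1NC(=O)/C=C/CN1CCCC1` is not yet measured. It differs from compound 2 by pyrrolidin-1-yl in place of ethyl on a saturated chain carbon bound to a double-bonded chain carbon. Among the compounds with values here, no measured step touches this position: the one step known, from compound 1 to compound 2, changes the shape of the chain itself rather than replacing a terminal group on a saturated chain carbon bound to a double-bonded chain carbon, so it offers no direct guide to the size or direction of the change in this assay. The expectation is therefore cautious, with a step of a 1.4-fold lower number from compound 2 to compound 3 (0.16 log units; within the scatter) that is estimated to be small and not clearly beyond the scatter. Compound 3 is expected to give about 2200 nM, within a range of 500 nM to 9000 nM.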

Compound 3, half-maximal inhibitory concentration: 1510 nM
Estimate against measurement, compound 3: 1.5-fold (0.16 log units) above, within the range that was stated.
By their numbers in this assay, from the lowest: compound 3; then compound 2; then compound 1.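

Working notes, continued. In this assay, within the data shown here, the change of ethyl to pyrrolidin-1-yl on a saturated chain carbon bound to a double-bonded chain carbon gives a 2.1-fold lower number from compound 2 to compound 3 (0.32 log units; beyond the scatter) and so shows, as no earlier step could, that the number responds to the group at this position, and that a terminal five-membered ring holding a nitrogen goes with a lower number than ethyl does. Set against the 2-methylprop-1-en-1-yl chain, the 3-(pyrrolidin-1-yl)prop-1-en-1-yl chain gives a 4.2-fold lower number from compound 1 to compound 3 (0.63 log units; beyond the scatter) and places compound 3 lowest of the three, with both of its steps beyond the scatter. Nothing in hand bears on why the number falls with this change.

The compounds shown do not separate the contribution of the nitrogen from that of the ring: a cyclopentyl group, an open dimethylamino group, or a piperidin-1-yl or morpholin-4-yl ring on the same carbon would address that. Also open, going by these compounds, is whether the step holds when the amine sits on a longer chain, or when a carboxylic acid takes its place.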